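Methyl for nitro on the ester aryl ring of compound 2

The source may hold more compounds than are shown below. What is called first, only, known or untested is meant among the compounds shown, and "the series" means these compounds.

Measured compounds:
compound 1 `COc1ccc(C2CC(=NOC(=O)c3cccc(Cl)c3)CC(c3ccc(OC)cc3)N2C)cc1` 136000 nM
compound 2 `COc1ccc(C2CC(=NOC(=O)c3ccc([N+](=O)[O-])cc3)CC(c3ccc(OC)cc3)N2C)cc1` 280000 nM
compound 3 `COc1ccc(C2CC(=NOC(=O)c3cc(O)c(O)c(O)c3)CC(c3ccc(OC)cc3)N2C)cc1` 18000 nM

In a functional assay, with a stated time of 30 min (on this read-out lower numbers stand for stronger inhibition and higher numbers for weaker inhibition), compound 2 gives the highest of the three numbers: compound 1 sits nearest, with a 2.1-fold higher number from compound 1 to compound 2 (0.31 log units; beyond the scatter) separating the two, and compound 3 lies furthest away, as a 16-fold lower number from compound 2 to compound 3 (1.19 log units; beyond the scatter) shows. The unmeasured compound 4 `COc1ccc(C2CC(=NOC(=O)c3ccc(C)cc3)CC(c3ccc(OC)cc3)N2C)cc1` keeps the whole core of compound 2 and changes only the substituent on the aryl ring of the ester: methyl in place of nitro on an aromatic carbon.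

Within the data shown here, no measured step exchanges nitro for methyl. Among the measured compounds shown here, two measured steps touch the same aryl ring: a 2.1-fold higher number from compound 1 to compound 2 (0.31 log units; beyond the scatter), where 3-chlorophenyl became 4-nitrophenyl, and a 16-fold lower number from compound 2 to compound 3 (1.19 log units; beyond the scatter), where the 4-nitrophenyl gave way to 3,4,5-trihydroxyphenyl. Both show that leaving the 4-nitrophenyl, or arriving at it, moves the read-out, and that compound 2 marks the weak end of this small set. Since compound 4 removes the nitro group, compound 4 is expected to fall somewhat below compound 2, a step of the size seen between compound 1 and compound 2 rather than the larger one to compound 3: a 1.9-fold lower number from compound 2 to compound 4 (0.27 log units; within the scatter) is the expected change. In this assay compound 4 is therefore estimated at 150000 nM, within a range from 60000 nM to 400000 nM.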

Compound 4, half-maximal inhibitory concentration: 368000 nM
Compound 4: the middle estimate sits 2.5-fold (0.39 log units) below what was measured; low and high end bracket the measured number.
By their numbers in this assay, from the lowest: compound 3; then compound 1; then compounds 2 and 4 (each within the scatter of the next).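

In this assay, the exchange of nitro for methyl on the aromatic carbon para to a large group stays within the scatter (a 1.3-fold higher number from compound 2 to compound 4 (0.12 log units; within the scatter)), even though a group of 3 heavy atoms with 2 hydrogen-bond acceptors gives way to one of 1 heavy atom with none. Removing the nitro group therefore does not by itself bring the number closer to the other two compounds, as compound 4 remains apart from both compound 1 (a 2.7-fold higher number from compound 1 to compound 4 (0.43 log units; beyond the scatter)) and compound 3 (a 20-fold higher number from compound 3 to compound 4 (1.31 log units; beyond the scatter)), so that compound 3, the only one of the four with more than one substituent on this ring, now stands clear of three singly substituted compounds. No measurement at hand accounts for any of these steps.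

The compounds shown leave open whether a single hydroxyl group at this para place, as in 4-hydroxyphenyl, would already move the number toward that of compound 3, or whether all three hydroxyl groups are needed. They also leave open how an amine or a carboxylic acid on the same aromatic carbon would read out next to the flat pair of nitro and methyl.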